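A few compounds are considered here, and "the series" means these few. Any claim that something is new, unique, unknown or untested is made for them only; others in the source may bear on it.

Measured compounds:
compound 1, `CC(Br)C(=O)Nc1cc(C(=O)NC(N)=O)ccc1Cl`: 9800 nM
compound 2, `COc1ccc(C(=O)NC(N)=O)cc1NC(=O)C(C)Br`: > 20000 nM
compound 3, `NC(=O)NC(=O)c1ccc(Cl)c(NC(=O)CBr)c1`: 2910 nM

All three were tested in a functional assay on CCRF-CEM cells (Homo sapiens) for antiproliferative activity, read by trypan blue exclusion, with a stated time of 72 h; on this read-out lower numbers stand for stronger inhibition and higher numbers for weaker inhibition. Compound 2 gives only a limit in this assay, > 20000 nM, which is the limit of > 20000 nM in this assay, at which 1 of the 3 values shown sits. The change methoxy in place of chloro on an aromatic carbon gave an at least 2.0-fold higher number from compound 1 to compound 2 (0.30 log units; that floor lies within the scatter). The change hydrogen in place of methyl on a saturated chain carbon bound to a bromine atom and a carbonyl carbon gave a 3.4-fold lower number from compound 1 to compound 3 (0.53 log units; beyond the scatter), leaving compound 3 with the lower of the two numbers. Compound 4, `COc1ccc(C(=O)NC(N)=O)cc1NC(=O)CBr`, is not yet measured; it differs from compound 3 by methoxy in place of chloro on an aromatic carbon, the same kind of change as from compound 1 to compound 2, though there the place is ortho to a ((1-bromoethyl)carbonyl)amino group and here ortho to a ((bromomethyl)carbonyl)amino group. Resting on compound 1 and its step of an at least 2.0-fold higher number from compound 1 to compound 2 (0.30 log units; that floor lies within the scatter), the step from compound 3 to compound 4 is expected to be a 3.1-fold higher number from compound 3 to compound 4 (0.49 log units; beyond the scatter). Compound 4 is estimated at 9000 nM, between 4000 nM and 25000 nM.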

Compound 4, half-maximal inhibitory concentration: 1880 nM
The estimate for compound 4 lay 4.8-fold (0.68 log units) above the measured number, outside the stated range (below it).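

In this assay, methoxy in place of chloro on an aromatic carbon gave a 1.5-fold lower number from compound 3 to compound 4 (0.19 log units; within the scatter), and this change did not behave alike on the two cores: the same change on two cores in this assay, an at least 2.0-fold higher number (0.30 log units; that floor lies within the scatter) from compound 1 to compound 2 and a 1.5-fold lower number (0.19 log units; within the scatter) from compound 3 to compound 4, at least 3.1-fold (0.49 log units) apart, beyond the scatter of two such steps. Hydrogen in place of methyl on the saturated chain carbon gave an at least 10-fold lower number from compound 2 to compound 4 (1.02 log units; beyond the scatter), the same direction as on the other core but a different size: the same change on two cores in this assay, a 3.4-fold lower number (0.53 log units; beyond the scatter) from compound 1 to compound 3 and an at least 10-fold lower number (1.02 log units; beyond the scatter) from compound 2 to compound 4, at least 3.1-fold (0.49 log units) apart, beyond the scatter of two such steps. Compound 2 gives only a limit, > 20000 nM, so both gaps are floors, and these pairs do not show why the steps differ or how either change would run on a further core: the limit of > 20000 nM in this assay, at which 1 of the 4 values shown sits.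

The compounds shown leave open how an amine in place of the chloro would behave on either core. They also leave open what a longer chain in place of the bromomethyl group would do.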